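Varying the amide substituent on a shared core

The source may report more compounds than this note shows. Statements on the series, on what has been measured and on what is new or still open speak of the compounds shown alone.

Going by the values given here, compound 2 `O=C1C=CC(=O)C(c2cc(-c3ccc(C(=O)N4CCC(C(F)(F)F)CC4)s3)on2)=C1` is one of three compounds measured in a functional assay on A549 cells (Homo sapiens) for cytotoxicity, read by XTT assay, with a stated time of 72 h; a higher number here means a weaker inhibitor, a lower number a stronger inhibitor. In this assay compound 2 reaches only a limit, > 30000 nM. Compound 1 `CN(C)C(=O)c1ccc(-c2cc(C3=CC(=O)C=CC3=O)no2)s1` likewise reaches only a limit, > 30000 nM. Compound 3 `CCN(CC)C(=O)c1ccc(-c2cc(-c3cc(OC)ccc3OC)no2)s1` gives 11000 nM. Among the compounds with values here, the single measured step that bears on the change ahead is a step that the two limits leave unreadable from compound 1 to compound 2, and its size cannot be read because both of its ends sit at the limit of > 30000 nM in this assay, at which 2 of the 3 values shown sit. Compound 4 `CN(Cc1ccccc1)C(=O)c1ccc(-c2cc(C3=CC(=O)C=CC3=O)no2)s1` differs from compound 2 by benzyl(methyl)amino in place of 4-(trifluoromethyl)piperidin-1-yl on a carbonyl carbon. One unreadable step gives no direction, so no change beyond the scatter is expected for compound 4, and another limit seems the most likely outcome. Compound 4 is therefore estimated at 30000 nM, within 8000 nM to 100000 nM. The expected step of a number no higher from compound 2 to compound 4 (the limit leaves the size open) is thus essentially none.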

Compound 4, half-maximal inhibitory concentration: > 30000 nM
Compound 4 gave a limit, no number; the forecaster's own chance of this, stated with the estimate: 70%; the middle value lies on the limit itself.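

No step among compound 1, compound 2 and compound 4 can be read, because each gives only a limit: the limit of > 30000 nM in this assay, at which 3 of the 4 values shown sit.

On these data alone, whether any of these amide groups changes inhibition on the shared core in this assay remains open.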